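Butyl to tert-Butyl on Sulfur: Expecting Compound 4

A few compounds are considered here, and "the series" means these few. Any claim that something is new, unique, unknown or untested is made for them only; others in the source may bear on it.

The study measured compounds sharing one core in an ADME assay on PBMC cells (Homo sapiens) for inhibition, read by MTT assay; a lower number here means a stronger inhibitor, a higher number a weaker inhibitor. Compound 1, `CCCCSC1=CC(=O)C(C[C@]2(C)[C@@H](C)CC[C@]3(C)C(C)=CCC[C@@H]23)=CC1=O`, returned "not determined" (no result reported) in this assay, so it stands without a number. Compound 3, `CCCCCCCCSC1=CC(=O)C(C[C@]2(C)[C@@H](C)CC[C@]3(C)C(C)=CCC[C@@H]23)=CC1=O`, likewise gave "not determined" (no result reported) in this assay. Among the measured compounds shown here, the single number comes from compound 2, `CC1=CCC[C@H]2[C@](C)(CC3=CC(=O)C(Sc4ccccc4)=CC3=O)[C@@H](C)CC[C@]12C`, which gives 11200 nM in this assay. With no numbered pair among the measured compounds, no step size is known.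

Compound 4, `CC1=CCC[C@H]2[C@](C)(CC3=CC(=O)C(SC(C)(C)C)=CC3=O)[C@@H](C)CC[C@]12C`, arises from compound 1 by tert-butyl in place of butyl on a sulfur. Since compound 1 has no number, the direction and size of the step to compound 4 in this assay cannot be anchored; nothing here forbids a step beyond the scatter in either direction, and nothing supports one. For the measured compounds named here, compound 2, with its different group on sulfur, gives 11200 nM and is the only guide. Compound 4 is therefore expected near 12000 nM in this assay, with a wide range from 3000 nM to 50000 nM.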

Compound 4, half-maximal inhibitory concentration: 20800 nM
Estimate against measurement, compound 4: 1.7-fold (0.24 log units) below; low and high end bracket the measured number.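

Among the compounds shown here, at the sulfur on the double-bonded ring carbon, tert-butyl in place of phenyl gives the first step that can be read in this assay, a 1.9-fold higher number from compound 2 to compound 4 (0.27 log units; within the scatter). The sulfur therefore carries either a phenyl ring or a branched tert-butyl group with no step beyond the scatter in this pair. For the compounds shown here, compound 1 and compound 3 have no number, so no step from either of them can be read, including butyl to tert-butyl. Nothing available explains the result.

The compounds shown leave open how a straight chain on this sulfur compares with tert-butyl or phenyl in this assay. They also leave open how a group such as an amine or a carboxylic acid on this sulfur would read.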